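Amine variation on the benzyl arm of a stilbene core

The compounds below may be only part of what the source reports. "The series", "measured", "known", "first", "only" and "open" are said of these compounds alone.

Measured so far in a functional assay on MC-38 cells (Mus musculus) for antiproliferative activity, read by CCK-8 assay, with a stated time of 48 h; a lower number here means a stronger inhibitor, a higher number a weaker inhibitor:
compound 1 `COc1ccc(/C=C\c2cc(OC)c(OC)c(OC)c2)cc1OCc1ccc(CN2CCCCC2C(=O)O)cc1` gives 5400 nM
compound 2 `COc1ccc(/C=C\c2cc(OC)c(OC)c(OC)c2)cc1OCc1ccc(CN[C@H](C(=O)O)[C@H](C)O)cc1` gives > 10000 nM, a limit of this assay
compound 3 `COc1ccc(/C=C\c2cc(OC)c(OC)c(OC)c2)cc1OCc1ccc(CN2CC[C@@H](C(=O)O)C2)cc1` gives 6300 nM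

Compound 1 has the lowest number among the two numbers given, while compound 3 is within the scatter of it (a 1.2-fold higher number from compound 1 to compound 3 (0.07 log units; within the scatter)). Compound 2 sits at the limit (the limit of > 10000 nM in this assay, at which 1 of the 3 values shown sits). The step of an at least 1.8-fold higher number from compound 1 to compound 2 (0.26 log units; that floor lies within the scatter) therefore only sets a floor.

Compound 4 `COc1ccc(/C=C\c2cc(OC)c(OC)c(OC)c2)cc1OCc1ccc(CN2CC[C@@H](O)C2)cc1` differs from compound 1 as follows: 3-hydroxypyrrolidin-1-yl in place of 2-carboxypiperidin-1-yl on a saturated chain carbon bound to an aromatic carbon. The step from compound 1 to compound 3 bears on this change in that the ring is altered while the carboxylic acid is retained, and it stays within the scatter. Among the compounds with values here, no measured step removes the carboxylic acid or introduces a hydroxyl, so the effect of that part of the change is not covered by the compounds measured here; the step from compound 1 to compound 2 changes the amine in a different way and is only a floor.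

For compound 4 the expected step is a 1.0-fold higher number from compound 1 to compound 4 (0.01 log units; within the scatter), with no clear direction beyond the scatter. Compound 4 is therefore estimated to give 5500 nM in this assay, within 1800 nM to 16000 nM.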

Compound 4, half-maximal inhibitory concentration: 6900 nM
Estimate against measurement, compound 4: 1.3-fold (0.10 log units) below, within the range that was stated.
By their numbers in this assay, from the lowest: compounds 1, 3 and 4 (each within the scatter of the next). At a limit, above all of these: compound 2.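

In this assay, hydroxy in place of carboxy on a saturated ring carbon gives a 1.1-fold higher number from compound 3 to compound 4 (0.04 log units; within the scatter), so compound 3 and compound 4 cannot be told apart. The wider exchange of 2-carboxypiperidin-1-yl for 3-hydroxypyrrolidin-1-yl gives a 1.3-fold higher number from compound 1 to compound 4 (0.11 log units; within the scatter), so ring size and the acid together also leave compounds 1, 3 and 4 unseparated on a saturated chain carbon bound to an aromatic carbon, and no group among these three can be ranked over another. Compound 2 stands at a limit: the limit of > 10000 nM in this assay, at which 1 of the 4 values shown sits. The step of an at least 1.4-fold lower number from compound 2 to compound 4 (0.16 log units; that floor lies within the scatter) therefore only sets a floor.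

Open, as far as these compounds go, is whether a ring amine with no oxygen-bearing group, such as piperidin-1-yl or pyrrolidin-1-yl, or a longer chain carrying the amine, would move the number beyond the scatter in this assay. Also open, from the compounds shown here alone, are how far the (1-carboxy-2-hydroxypropyl)amino group of compound 2 truly lies from the ring amines, and whether the opposite configuration of the 3-hydroxypyrrolidin-1-yl stereocentre would read any differently.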